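Methoxy for (trifluoromethyl)carbonyl across two cores

The compounds below may be only part of what the source reports. "The series", "measured", "known", "first", "only" and "open" are said of these compounds alone.

Compound 1 `O=C(CCCCCCc1ccccc1)c1nc(C(=O)C(F)(F)F)co1` gives 123 nM in an assay on HEK-293T cells for inhibition of diacylglycerol lipase-alpha (Homo sapiens), read by colorimetric assay; on this read-out lower numbers stand for stronger inhibition and higher numbers for weaker inhibition. Compound 2 `COc1coc(C(=O)CCCCCCc2ccccc2)n1` differs by methoxy in place of (trifluoromethyl)carbonyl on an aromatic carbon. In this assay compound 2 is reported only as a limit, > 10000 nM. The step of an at least 81-fold higher number from compound 1 to compound 2 (1.91 log units; beyond the scatter) is large; its true size is open, because the limit of > 10000 nM in this assay, at which 2 of the 3 values shown sit, caps what the assay reports. Compound 3 `O=C(CCCCCCc1ccccc1)c1ncc(-c2ccc(C(=O)C(F)(F)F)cc2)o1` likewise appears in this assay only as a limit, > 10000 nM. How the core of compound 3 differs from the core of compound 1 is not broken down here. Compound 4 `COc1ccc(-c2cnc(C(=O)CCCCCCc3ccccc3)o2)cc1` carries methoxy in place of (trifluoromethyl)carbonyl on an aromatic carbon, the same kind of change as from compound 1 to compound 2, but at a different place: a six-membered aromatic ring of carbon only, para to a large group, instead of a five-membered aromatic ring with 1 nitrogen and 1 oxygen, next to the ring nitrogen. Since compound 3 already sits at the limit > 10000 nM, compound 4 is expected to stay there, with an expected step that the limit leaves unreadable from compound 3 to compound 4. The estimate for compound 4 in this assay is 25000 nM, between 10000 nM and 100000 nM.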

Compound 4, half-maximal inhibitory concentration: > 10000 nM
Compound 4: only a limit was reported (the forecaster's own chance of this, stated with the estimate: 88%); the middle value lies beyond the limit too.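

No step from compound 3 to compound 4 can be read in this assay, because both stand only as limits: the limit of > 10000 nM in this assay, at which 3 of the 4 values shown sit.

The compounds shown leave open how methoxy in place of (trifluoromethyl)carbonyl acts on the core of compound 3.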